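Working notes: methoxy added to the phenyl of compound 2

A few compounds are considered here, and "the series" means these few. Any claim that something is new, unique, unknown or untested is made for them only; others in the source may bear on it.

Measured so far:
compound 1 `CCc1nnc(-c2nsc3ccccc23)o1` — 10%
compound 2 `c1ccc(-c2nnc(-c3nsc4ccccc34)o2)cc1` — 60%

In a functional assay on the whole organism for inhibition, with Rattus norvegicus as the target, with a stated time of 2 h, at a dose of 100 mg/kg by the intraperitoneal route (a lower number here means less inhibition, a higher number more inhibition at the dose given (going by the name of the read-out)), compound 2 gives 60%, the highest of the two numbers; nearest is compound 1 with 10%. The step of a number 50 percentage points higher from compound 1 to compound 2 (beyond the scatter) came with phenyl in place of ethyl on an aromatic carbon. Compound 3 `COc1ccc(-c2nnc(-c3nsc4ccccc34)o2)cc1` differs from compound 2 by methoxy in place of hydrogen on an aromatic carbon. Within the data shown here, no measured step involves a methoxy; the only step, a number 50 percentage points higher from compound 1 to compound 2 (beyond the scatter), concerns another change and does not bear on this one. The step of no change at the digits printed from compound 2 to compound 3 (within the scatter) is therefore expected to be none beyond the scatter. Compound 3 is expected to give 60%, within 35% to 85%.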

Compound 3, a percentage reported as inhibition, in the whole organism at one dose (the size of the read-out at that dose, not a potency): 45%
Compound 3: middle estimate off by 15 percentage points, on the high side, within the range that was stated.
By their numbers in this assay, from the lowest: compound 1; then compound 3; then compound 2.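

In this assay, the phenyl of compound 2 proves sensitive to substitution at the place para to a large group: methoxy in place of hydrogen there gives a number 15 percentage points lower from compound 2 to compound 3 (beyond the scatter). Among these compounds, this is the first sign that a small addition to the phenyl, and not only the exchange of ethyl for phenyl, moves the read-out. Nothing at hand accounts for this step. Still open, as far as these compounds go, is whether an amine or a carboxylic acid at this place would go the same way as methoxy, and whether the step is specific to methoxy.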